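Nitrogen substituent swap from compound 2 to compound 3

The compounds below may be only part of what the source reports. "The series", "measured", "known", "first", "only" and "open" are said of these compounds alone.

Values in an ADME assay on L929 cells (Mus musculus) for cytotoxicity, read by resazurin assay, with a stated time of 48 h (a higher number here means that more compound is tolerated, a lower number that less compound is tolerated), are as follows.
- Compound 1 `C#CCn1c2ccc([N+](=O)[O-])cc2c(=O)n1Cc1ccccc1` gives 195000 nM
- Compound 2 `CN(C)C(=O)CCCn1c2ccc([N+](=O)[O-])cc2c(=O)n1Cc1ccccc1` gives > 256000 nM, which is a limit

Compound 2 stands only at a limit, (the limit of > 256000 nM in this assay, at which 1 of the 2 values shown sits). Compound 3 `CCOC(=O)n1c2ccc([N+](=O)[O-])cc2c(=O)n1Cc1ccccc1` carries ethoxycarbonyl in place of 3-(dimethylcarbamoyl)propyl on an aromatic nitrogen, (ethoxycarbonyl in place of 3-(dimethylcarbamoyl)propyl on an aromatic nitrogen). Among the measured compounds shown here, the only measured step bearing on this is an at least 1.3-fold higher number from compound 1 to compound 2 (0.11 log units; that floor lies within the scatter), and its floor lies within the scatter, so it sets no firm size. For the measured compounds named here, the one actual number in this assay is that of compound 1, 195000 nM. The expected change is a modest fall, an at least 1.6-fold lower number from compound 2 to compound 3 (0.20 log units; that floor lies within the scatter). For compound 3 the estimate is 160000 nM, with an expected range of 60000 nM to 256000 nM.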

Compound 3, concentration lethal to 50% of the cells: 122000 nM
The estimate for compound 3 lay 1.3-fold (0.12 log units) above the measured number; low and high end bracket the measured number.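

In this assay, this aromatic nitrogen now shows a change beyond the scatter, with ethoxycarbonyl in place of 3-(dimethylcarbamoyl)propyl (an at least 2.0-fold lower number from compound 2 to compound 3 (0.32 log units; beyond the scatter)). That size is only a floor, and compound 2 stands at a limit: the limit of > 256000 nM in this assay, at which 1 of the 3 values shown sits. Ethoxycarbonyl and propargyl remain within the scatter of each other (a 1.6-fold lower number from compound 1 to compound 3 (0.20 log units; within the scatter)), so the separation appears only against 3-(dimethylcarbamoyl)propyl.

On these data alone, it remains open how far above its limit compound 2 lies. Also open, as far as these compounds go, is how a carboxylic acid or an amine at the end of a chain on this nitrogen would read in this assay.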